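Phenyl to Hydrogen on the Shared Core: Expected Permeability

The source may report more compounds than this note shows. Statements on the series, on what has been measured and on what is new or still open speak of the compounds shown alone.

Compound 1 `N#Cc1c(N)nc(NCCCC2CCN(Cc3ccccc3)CC2)c(C#N)c1-c1ccccc1` gives 31.6 10^-6 cm/s in an ADME assay for permeability, using PAMPA, in phosphate buffer, with a stated time of 4 h, tested at 1 mg/mL; on this read-out higher numbers stand for higher permeability and lower numbers for lower permeability.
Compound 2 `N#Cc1cc(C#N)c(NCCCCC2CCN(Cc3ccccc3)CC2)nc1N` gives 21.2 10^-6 cm/s in this assay.

Going by the values given here, of the two numbers measured so far, compound 1 has the higher one, but its nearest neighbour, compound 2, lies within the usual scatter of it, so the two cannot be ordered with any confidence. Among the compounds with values here, no pair of these two compounds differs in one place only, and therefore no single-change step is available from them.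

Compound 3 `N#Cc1cc(C#N)c(NCCCC2CCN(Cc3ccccc3)CC2)nc1N` is the unmeasured member. It differs from compound 1 by hydrogen in place of phenyl on an aromatic carbon. Compound 3 shares with compound 2 the absence of that phenyl group and differs from it only in the length of the chain that joins the core to the piperidine, so compound 2 is the closer reference for what to expect. Because compound 2 gives 21.2 10^-6 cm/s, compound 3 is expected to land in the same region, and the step from compound 1 to compound 3 is estimated as a 1.7-fold lower number from compound 1 to compound 3 (0.22 log units; within the scatter), a modest move downward. Compound 3 is therefore estimated at 19 10^-6 cm/s, with a range from 9 10^-6 cm/s to 38 10^-6 cm/s.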

Compound 3, apparent permeability: 20.8 10^-6 cm/s
Compound 3: middle estimate off by 1.1-fold (0.04 log units), on the low side, within the range that was stated.
By their numbers in this assay, from the lowest: compounds 3, 2 and 1 (each within the scatter of the next).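

Going by these compounds alone, this step is the first single change in the set: in this assay, hydrogen in place of phenyl on the aromatic carbon opposite the ring nitrogen gives a 1.5-fold lower number from compound 1 to compound 3 (0.18 log units; within the scatter). A whole group of 6 heavy atoms, one six-membered aromatic ring of carbon only, thus leaves this place, ortho to two cyano groups, and the read-out stays within the usual scatter, so with this chain the position shows no difference that can be told apart between phenyl and hydrogen. No measurement is at hand that could account for this result, and it stands here as an observation only.

The compounds shown carry only phenyl or hydrogen at this position, so it remains open whether another group there, such as an amine, a methoxy group or a carboxylic acid, would also stay within the scatter. From the compounds shown here alone, it is equally open whether phenyl at this place would give a similar step on the longer chain that compound 2 carries between the core and the piperidine.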